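This account rests on a few compounds, and the source may have more. Where it says the series, first, only, none or still open, it means among the compounds named here.

Measured in a functional assay on CEM-DNR-bulk cells (Homo sapiens), read by MTT assay, with a stated time of 72 h; on this read-out higher numbers stand for weaker inhibition and lower numbers for stronger inhibition:
- compound 1 `CSc1ncnc2c1c(-c1cccs1)cn2[C@@H]1O[C@H](CO)[C@@H](O)[C@H]1O`: > 20000 nM
- compound 2 `CNc1ncnc2c1c(-c1cccs1)cn2[C@@H]1O[C@H](CO)[C@@H](O)[C@H]1O`: > 20000 nM
- compound 3 `Cc1ncnc2c1c(-c1ccoc1)cn2[C@@H]1O[C@H](CO)[C@@H](O)[C@H]1O`: > 20000 nM

Each of these values is a limit of this assay, not a number. Among the measured compounds shown here, the series so far therefore shows only (the limit of > 20000 nM in this assay, at which 3 of the 3 values shown sit). As far as these compounds go, compound 3 sits at that same limit, so its true position is unknown.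

Compound 4 `Cc1ncnc2c1c(-c1cccs1)cn2[C@@H]1O[C@H](CO)[C@@H](O)[C@H]1O` has thiophen-2-yl in place of furan-3-yl on an aromatic carbon. For the measured compounds named here, the only measured step, a step that the two limits leave unreadable from compound 1 to compound 2, is made at a different place and gives no size to carry over. Compound 1 and compound 2 do carry thiophen-2-yl, yet neither returns a number in this assay. No step beyond the scatter is therefore expected, and a further limit is the likeliest result, although a measurable value cannot be excluded.

The estimated step is a number no higher from compound 3 to compound 4 (the limit leaves the size open). Compound 4 is expected at 20000 nM, with an estimated range of 4000 nM to 20000 nM.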

Compound 4, half-maximal inhibitory concentration: > 20000 nM
Compound 4 was reported as a limit; the forecaster's own chance of this, stated with the estimate: 70%; the middle value sits exactly at the limit.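

Compound 4 returns a limit, not a number, in this assay, so no step can be read among compound 1, compound 2, compound 3 and compound 4, each of which sits at a limit: the limit of > 20000 nM in this assay, at which 4 of the 4 values shown sit.

Whether any of these compounds is a stronger inhibitor than another, and by how much, remains open.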